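Side-chain exchange on the series core: compound 2 to compound 3

The compounds below may be only part of what the source reports. "The series", "measured", "known", "first", "only" and "open" are said of these compounds alone.

In an ADME assay on Huh7.5.1 cells (Homo sapiens) for cytotoxicity, read by WST assay, with a stated time of 48 h (on this read-out higher numbers stand for lower toxicity in this test and lower numbers for higher toxicity in this test), compound 1 `Cc1c(-c2ccc(Cc3ccc(OCC(F)(F)F)cc3)cc2)[nH]c2cccc(F)c2c1=O` gives > 5000 nM, which is a limit of the assay and not a number. Compound 2 `Cc1c(-c2ccc(Cc3ccc(C(O)C(F)(F)F)cc3)cc2)[nH]c2cccc(F)c2c1=O` gives > 10000 nM, also a limit and not a number, so its standing in this assay is known only as that limit. For the measured compounds named here, the one measured step bearing on the next change is a step that the two limits leave unreadable from compound 1 to compound 2, and it offers no size to carry forward. Compound 3 `Cc1c(-c2ccc(Cc3ccc([S+]([O-])C(F)(F)F)cc3)cc2)[nH]c2cccc(F)c2c1=O` is not yet measured and differs from compound 2 by a group of 6 heavy atoms (1 carbon, 1 oxygen, 3 fluorine, 1 sulfur; no ring) in place of a group of 6 heavy atoms (2 carbon, 1 oxygen, 3 fluorine; no ring), on an aromatic carbon. The expectation rests on compound 2, whose > 10000 nM is a limit. The expected a number no higher from compound 2 to compound 3 (the limit leaves the size open) is estimated to be no move beyond the scatter, in either direction. For compound 3 the estimate is 10000 nM, with an expected range from 4000 nM to 25000 nM.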

Compound 3, half-maximal cytotoxic concentration: > 5000 nM
Compound 3 ended at the assay's limit (the forecaster's own chance of this, stated with the estimate: 75%); the middle value does not contradict the limit.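

For the compounds shown here, compound 3 gives > 5000 nM in this assay, a limit and not a number, so no step linking it to compound 1 or compound 2 can be read. Going by these compounds, how far each of the three compounds lies past its limit, and whether their side chains separate them at all, stays open.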